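The source may hold more compounds than are shown below. What is called first, only, known or untested is meant among the compounds shown, and "the series" means these compounds.

Two compounds here share one core and differ only at one position on the aromatic ring attached to it. Compound 1 `CCOC(=O)c1cnn(-c2nc(-c3ccccc3F)c(C#N)c(=O)n2C)c1N` bears a fluoro group there, and in a functional assay, with a stated time of 20 min (on this read-out lower numbers stand for stronger inhibition and higher numbers for weaker inhibition), compound 1 gives 69 ug/mL. Compound 2 `CCOC(=O)c1cnn(-c2nc(-c3ccccc3O)c(C#N)c(=O)n2C)c1N` bears a hydroxy group instead, and in this assay compound 2 gives 48 ug/mL. Among the measured compounds shown here, the only measured step, a 1.4-fold lower number from compound 1 to compound 2 (0.16 log units; within the scatter), stays within the scatter, so compound 2 stands together with compound 1 in a single band rather than apart from it. Compound 3 `CCOC(=O)c1cnn(-c2nc(-c3ccco3)c(C#N)c(=O)n2C)c1N` has not yet been measured. It differs from compound 2 in one place: furan-2-yl in place of 2-hydroxyphenyl on an aromatic carbon. For the measured compounds named here, no measured step exchanges a six-membered aromatic ring of carbon only for a five-membered aromatic ring with one hetero atom, so nothing known speaks directly to this change; the one step that is known, a 1.4-fold lower number from compound 1 to compound 2 (0.16 log units; within the scatter), shows only that altering this group at one point left the read-out inside the scatter. On that basis the estimated step of a 1.0-fold higher number from compound 2 to compound 3 (0.02 log units; within the scatter) is small, with wide uncertainty. Compound 3 is therefore expected to give about 50 ug/mL, within a range from 20 ug/mL to 125 ug/mL.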

Compound 3, half-maximal inhibitory concentration: 91 ug/mL
The estimate for compound 3 lay 1.8-fold (0.26 log units) below the measured number, and the stated range covers the measured number.
By their numbers in this assay, from the lowest: compounds 2, 1 and 3 (each within the scatter of the next).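

Earlier, only a fluoro or a hydroxy group on the phenyl ring had changed. Compound 3 shows that the whole 2-hydroxyphenyl group can be exchanged for furan-2-yl, a five-membered aromatic ring, and in this assay the read-out still stays inside the scatter, with a 1.9-fold higher number from compound 2 to compound 3 (0.28 log units; within the scatter) and with a 1.3-fold higher number from compound 1 to compound 3 (0.12 log units; within the scatter) for the exchange of 2-fluorophenyl. At this place, ortho to a cyano group and next to the ring nitrogen, neither a six-membered aromatic ring of carbon only nor a hydrogen-bond donor is therefore needed to keep the number within the scatter of the other two compounds. Nothing measured here offers a reason for these numbers.

On these data alone, all three compounds fall in one band, so it remains unknown what kind of group at this place, if any, would move the number beyond the scatter. As far as these compounds go, whether an amine, a carboxylic acid, a longer chain or a thiophene-2-yl ring would do so stays open, and so does whether any change here could bring a clearly stronger inhibition.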